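The source may report more compounds than this note shows. Statements on the series, on what has been measured and on what is new or still open speak of the compounds shown alone.

Compounds measured in a toxicity assay on NIH3T3 cells (Mus musculus) for cytotoxicity, read by resazurin assay; on this read-out higher numbers stand for an effect only at larger amounts of compound and lower numbers for an effect already at smaller amounts:

- compound 1, `COC(=O)c1ccc(NCc2cncn2Cc2cccc(Br)c2)cc1-c1ccccc1` — in this assay compound 1 gives > 10000 nM, which is a limit of the assay and not a number.
- compound 2, `COC(=O)c1ccc(NCc2cncn2Cc2ccc(N)cc2)cc1-c1ccccc1` — in this assay compound 2 gives > 10000 nM, again only a limit.
- compound 3, `COC(=O)c1ccc(NCc2cncn2Cc2ccccc2-c2ccccc2)cc1-c1ccccc1` — in this assay compound 3 gives "not determined" (no result reported), that is, no result reported.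

For the measured compounds named here, only one step between measured compounds exists here, a step that the two limits leave unreadable from compound 1 to compound 2, and its size cannot be read: the limit of > 10000 nM in this assay, at which 2 of the 3 values shown sit. Compound 3 therefore stands nowhere on the numbers shown; it has no value in this assay, and the two values that do exist for the series are both limits.

The next compound, compound 4, is `COC(=O)c1ccc(NCc2cncn2Cc2cccc(C)c2)cc1-c1ccccc1`. The change from compound 3 is 3-methylphenyl in place of 2-phenylphenyl on a saturated chain carbon bound to an aromatic nitrogen. Going by the values given here, no measured step bears on this change, since the only measured pair, compound 1 and compound 2, differs in another group and gives no readable size. What the series shows so far is simply that neither measured compound reached a half-maximal effect within the tested range.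

On that basis compound 4 is expected to behave like the measured compounds and give about 15000 nM in this assay, with a range from 5000 nM to 50000 nM, and it is expected that the assay will most likely report only a limit for compound 4 rather than a number.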

Compound 4, half-maximal effective concentration: > 10000 nM
Compound 4: a limit, no number; the forecaster's own chance of this, stated with the estimate: 80%; the middle value lies beyond the limit too.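

In this assay compound 4 gives > 10000 nM as a limit of the assay and not a number. For the compounds shown here, no step to compound 4 from compound 1 or compound 2 can be read, since all three results are limits: the limit of > 10000 nM in this assay, at which 3 of the 4 values shown sit. The compounds shown leave open at what concentration, if any, a half-maximal effect appears in this series.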